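Moving a chlorine on a benzyl group in cytotoxicity testing

This account rests on a few compounds, and the source may have more. Where it says the series, first, only, none or still open, it means among the compounds named here.

compound 1 `O=C1c2ccccc2N(Cc2ccccc2)S(=O)(=O)N1Cc1ccc(Cl)cc1` — 121000 nM
compound 2 `O=C(OCOCN1c2ccccc2C(=O)N(Cc2ccccc2)S1(=O)=O)c1ccccc1` — 37000 nM
compound 3 `O=C1c2ccccc2N(Cc2ccc(Cl)c(Cl)c2)S(=O)(=O)N1Cc1ccccc1` — a limit, > 200000 nM

In a functional assay on HEL cells (Homo sapiens) for inhibition (a higher number here means that more compound is tolerated, a lower number that less compound is tolerated), compound 1 gives 121000 nM, the highest of the two plain numbers. Compound 2 gives 37000 nM, a lower number, and the gap to compound 1 lies beyond the usual scatter of this assay. Going by the values given here, for compound 3 the measurement is a limit, not a number, and compound 3 is the one compound sitting at the limit of > 200000 nM in this assay, at which 1 of the 3 values shown sits.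

Compound 4 `O=C1c2ccccc2N(Cc2ccccc2)S(=O)(=O)N1Cc1ccccc1Cl` has the same atoms as compound 1, joined differently: 2-chlorophenyl in place of 4-chlorophenyl on a saturated chain carbon bound to an amide-type nitrogen in a ring. Among the compounds with values here, no pair of measured compounds differs in this one place, so the data give no direct guide to the size or direction of such a move. The chlorine stays on the same ring, attached to the same nitrogen, and the molecule keeps its size and its count of donors and acceptors, so the step from compound 1 to compound 4 is expected to be small, likely none beyond the scatter, with a slight lean toward more compound being tolerated. Compound 4 is therefore estimated at 130000 nM, within 50000 nM to 200000 nM, an expected step of a 1.1-fold higher number from compound 1 to compound 4 (0.03 log units; within the scatter).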

Compound 4, half-maximal cytotoxic concentration: > 200000 nM
Compound 4 ended at the assay's limit; the forecaster's own chance of this, stated with the estimate: 25%; middle value at least 1.5-fold (0.18 log units) away from the limit.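

This is the only pair shown that differs in one place, so the swap of 2-chlorophenyl for 4-chlorophenyl on a saturated chain carbon bound to an amide-type nitrogen in a ring can now be read directly in this assay: the change gives an at least 1.6-fold higher number from compound 1 to compound 4 (0.21 log units; that floor lies within the scatter). From the compounds shown here alone, the result for compound 4 is a limit, not a number, so this step is only a floor; the true size of the step stays unknown, and the floor alone does not show a real gain in how much compound is tolerated. Compound 4 also joins the one other compound at the top of the range tested: the limit of > 200000 nM in this assay, at which 2 of the 4 values shown sit.

Going by these compounds, whether an amine or a methoxy group in place of the chlorine on the 2-chlorophenyl would stay at this limit remains open, as does the effect of a longer chain carrying the chlorophenyl. A single pair also leaves open whether the same move of the chlorine would give a similar step on other compounds built on the shared core.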